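From ethoxy to diethylamino in a level series

This account rests on a few compounds, and the source may have more. Where it says the series, first, only, none or still open, it means among the compounds named here.

Of the compounds shown here, three sharing one core have been measured in a functional assay on A549 cells (Homo sapiens) for antiproliferative activity, read by MTT assay, with a stated time of 48 h; on this read-out higher numbers stand for weaker inhibition and lower numbers for stronger inhibition. Compound 1 `COc1ccc(/C=C/c2cc(OC)cc(OC)c2/C=C/C(=O)c2ccc(C(F)(F)F)cc2)cc1`, which carries trifluoromethyl, gives 7.8 ug/mL. Compound 2 `COc1ccc(/C=C/c2cc(OC)cc(OC)c2/C=C/C(=O)c2ccc(F)cc2)cc1`, which carries fluoro, gives 6.6 ug/mL. Compound 3 `CCOc1ccc(C(=O)/C=C/c2c(/C=C/c3ccc(OC)cc3)cc(OC)cc2OC)cc1`, which carries ethoxy, gives 7.5 ug/mL. These three numbers all lie within the usual scatter of one another, so compound 3 stands level with the other two and holds no real rank among them.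

The next structure, compound 4 `CCN(CC)c1ccc(C(=O)/C=C/c2c(/C=C/c3ccc(OC)cc3)cc(OC)cc2OC)cc1`, exchanges a single group: diethylamino in place of ethoxy on an aromatic carbon. Diethylamino takes the place of ethoxy on an aromatic carbon, para to a large group. Three measured steps changed the group at this same place: a 1.2-fold lower number from compound 1 to compound 2 (0.07 log units; within the scatter), a 1.0-fold lower number from compound 1 to compound 3 (0.02 log units; within the scatter) and a 1.1-fold higher number from compound 2 to compound 3 (0.06 log units; within the scatter), so the expectation in this assay is no step beyond the scatter, in either direction. Among the measured compounds shown here, the guide is limited, however, as no measured compound carries diethylamino, and three compounds are few. The expected step is a 1.1-fold lower number from compound 3 to compound 4 (0.03 log units; within the scatter). For compound 4 the estimated value is 7 ug/mL, with an expected range from 3.5 ug/mL to 14 ug/mL.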

Compound 4, half-maximal inhibitory concentration: 5.4 ug/mL
Compound 4: the middle estimate sits 1.3-fold (0.11 log units) above what was measured; the range from low to high includes it.
By their numbers in this assay, from the lowest: compounds 4, 2, 3 and 1 (each within the scatter of the next).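

Diethylamino is the largest group yet placed at this position, with five heavy atoms against the three of ethoxy, and it brings nitrogen where ethoxy brought oxygen. Even so, this assay shows only a small difference (a 1.4-fold lower number from compound 3 to compound 4 (0.14 log units; within the scatter)), so this exchange of ethoxy for a larger amine group does not move the result outside normal assay variation. The comparisons with the other two groups agree (a 1.2-fold lower number from compound 2 to compound 4 (0.09 log units; within the scatter)) and (a 1.4-fold lower number from compound 1 to compound 4 (0.16 log units; within the scatter)), so all four groups on this aromatic carbon, para to a large group, now stand level, and no measurement shown here offers an explanation for that.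

The compounds shown leave open whether a carboxylic acid, a plain amino group or a hydroxyl at this position would also stay level, or whether a group containing a ring, such as morpholine, would produce a step beyond the scatter. They also leave open how the numbers would respond to a change elsewhere in the shared core, such as replacing one of its methoxy groups with a longer ethoxy or propoxy chain.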